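This account rests on a few compounds, and the source may have more. Where it says the series, first, only, none or still open, it means among the compounds named here.

In a functional assay on SJSA-1 cells (Homo sapiens) for inhibition, read by CCK-8 assay, with a stated time of 72 h, tested at 1 uM (on this read-out higher numbers stand for more inhibition at the one concentration tested (going by the name of the read-out) and lower numbers for less inhibition), compound 1 `O=C(NCCCCc1ccccc1)c1cccc(C2SCC(=O)N2c2ccccc2)c1` gives 73%, compound 2 `O=C(NCCCCc1ccccc1)c1cccc(C2SCC(=O)N2c2cccc(F)c2)c1` gives 80%, and compound 3 `COc1cccc(OC)c1N1C(=O)CSC1c1cccc(C(=O)NCCCCc2ccccc2)c1` gives 72%. Compound 3 sits at the bottom of these three numbers, yet only within the scatter: a number 1 percentage points lower from compound 1 to compound 3 (within the scatter) and a number 8 percentage points lower from compound 2 to compound 3 (within the scatter). Compound 4 `CC(F)(F)c1cccc(N2C(=O)CSC2c2cccc(C(=O)NCCCCc3ccccc3)c2)c1` differs from compound 3 by a group of 10 heavy atoms (8 carbon, 2 fluorine; one six-membered aromatic ring of carbon only) in place of a group of 10 heavy atoms (8 carbon, 2 oxygen; one six-membered aromatic ring of carbon only), on an amide-type nitrogen in a ring. The two measured changes on the same amide-type nitrogen bear on this step, a number 7 percentage points higher from compound 1 to compound 2 (within the scatter) and a number 1 percentage points lower from compound 1 to compound 3 (within the scatter), and neither left the scatter, so no change beyond the scatter is expected for compound 4 in this assay, with an expected step of a number 1 percentage points higher from compound 3 to compound 4 (within the scatter). Compound 4 is therefore estimated to give 73%, in the range 60% to 85%.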

Compound 4, a percentage reported as inhibition, at one concentration (the size of the read-out at that concentration, not a potency): 68%
Estimate against measurement, compound 4: 5 percentage points above; the measured number falls inside the stated range.
By their numbers in this assay, from the lowest: compounds 4, 3, 1 and 2 (each within the scatter of the next, the first and the last beyond it).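

In this assay a change on this aromatic ring now leaves the scatter: 1,1-difluoroethyl in place of fluoro gives a number 12 percentage points lower from compound 2 to compound 4 (beyond the scatter) and so separates the two substituted rings. The same group in place of hydrogen gives a number 5 percentage points lower from compound 1 to compound 4 (within the scatter) and the swap for 2,6-dimethoxyphenyl gives a number 4 percentage points lower from compound 3 to compound 4 (within the scatter) so compound 4 stands apart only from compound 2. No measurement here gives a reason for this. From the compounds shown here alone, whether an amine or a carboxylic acid on this ring would move the number beyond the scatter from compound 1 remains open.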